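Moving the Fluorine on the Benzyl Ether

The source may hold more compounds than are shown below. What is called first, only, known or untested is meant among the compounds shown, and "the series" means these compounds.

Measured so far in a functional assay on SW-620 cells (Homo sapiens) for inhibition, read by MTT assay, with a stated time of 48 h; on this read-out higher numbers stand for weaker inhibition and lower numbers for stronger inhibition:
compound 1 `Cc1ccc(NC(=O)NC(=O)c2ccc(OCc3cccc(Cl)c3)cc2)cc1-c1nc2ccccc2[nH]1`: 16000 nM
compound 2 `Cc1ccc(NC(=O)NC(=O)c2ccc(OCc3cccc(F)c3)cc2)cc1-c1nc2ccccc2[nH]1`: 39600 nM

Compound 2 stands at the higher of the two numbers in this assay. Within the data shown here, its only neighbour is compound 1, and the gap between them is a halogen exchange, a 2.5-fold higher number from compound 1 to compound 2 (0.39 log units; beyond the scatter), which counts as beyond the scatter but remains modest.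

Compound 3 `Cc1ccc(NC(=O)NC(=O)c2ccc(OCc3ccc(F)cc3)cc2)cc1-c1nc2ccccc2[nH]1` is the next compound in line. It differs from compound 2 by 4-fluorophenyl in place of 3-fluorophenyl on a saturated chain carbon bound to an oxygen on an aromatic ring. Among the measured compounds shown here, no measured pair speaks to a change of this kind: the one step known, a 2.5-fold higher number from compound 1 to compound 2 (0.39 log units; beyond the scatter), swaps one halogen for another at an unchanged ring position, and nothing here shows what a shift of the fluorine to another position does. For the measured compounds named here, with no bearing step, the writer expects no change beyond the scatter. The expected step is a 1.1-fold lower number from compound 2 to compound 3 (0.04 log units; within the scatter). Compound 3 is therefore estimated at 36000 nM, with a range from 12000 nM to 100000 nM.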

Compound 3, half-maximal inhibitory concentration: 35100 nM
Compound 3: middle estimate off by 1.0-fold (0.01 log units), on the high side; the range from low to high includes it.
By their numbers in this assay, from the lowest: compound 1; then compounds 3 and 2 (each within the scatter of the next).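

In this assay, shifting the fluorine from 3-fluorophenyl to 4-fluorophenyl gives a 1.1-fold lower number from compound 2 to compound 3 (0.05 log units; within the scatter) and so stays within the scatter, the first sign that this fluorine shift on the benzyl ether makes no measurable difference. The step that changes both halogen and ring position, a 2.2-fold higher number from compound 1 to compound 3 (0.34 log units; beyond the scatter), lies beyond the scatter but is modest, and it matches in size the halogen exchange alone, a 2.5-fold higher number from compound 1 to compound 2 (0.39 log units; beyond the scatter), so among these three compounds only compound 1 stands apart. Nothing available gives a reason for either step.

On these data alone, whether chloro tolerates the same shift as fluoro remains open. So does the effect of a different group on this ring, such as an amine or a carboxylic acid, or of a longer chain linking it to the oxygen.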